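This account rests on a few compounds, and the source may have more. Where it says the series, first, only, none or still open, it means among the compounds named here.

In an ADME assay on HepG2 2.2.15 cells (Homo sapiens) for cytotoxicity (on this read-out higher numbers stand for lower toxicity in this test and lower numbers for higher toxicity in this test), compound 1 `CC(=O)NCC(=O)OCCc1c(-c2ccccc2Cl)c2cc(Cl)ccc2[nH]c1=O` gives 110000 nM, while compound 2 `O=C(OCCc1c(-c2ccccc2Cl)c2cc(Cl)ccc2[nH]c1=O)c1cccnc1` gives 170000 nM. Going by the values given here, on these two numbers compound 2 stands next to compound 1, the single measured step being a 1.5-fold higher number from compound 1 to compound 2 (0.19 log units; within the scatter), which lies within the scatter. Among the compounds with values here, compound 3 `O=C(/C=C/c1cccnc1)OCCc1c(-c2ccccc2Cl)c2cc(Cl)ccc2[nH]c1=O` differs from compound 2 in one place: 2-(pyridin-3-yl)ethenyl in place of pyridin-3-yl on a carbonyl carbon Only that one step between compound 1 and compound 2 bears on this change, and it stayed within the scatter, so in this assay no shift beyond the scatter is expected. The expected step is a 1.1-fold lower number from compound 2 to compound 3 (0.05 log units; within the scatter). For compound 3 the estimate is 150000 nM, with a range from 60000 nM to 350000 nM.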

Compound 3, half-maximal cytotoxic concentration: 39000 nM
The estimate for compound 3 lay 3.8-fold (0.59 log units) above the measured number; measured number below the stated range.
By their numbers in this assay, from the lowest: compound 3; then compounds 1 and 2 (each within the scatter of the next).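

In this assay, going by these compounds alone, 2-(pyridin-3-yl)ethenyl on the carbonyl carbon brings a 4.4-fold lower number from compound 2 to compound 3 (0.64 log units; beyond the scatter) and is the first step at this position to go beyond the scatter. The same group in place of acetamidomethyl brings a 2.8-fold lower number from compound 1 to compound 3 (0.45 log units; beyond the scatter) so this position is not indifferent to the group it carries, and here the lower number stands for higher toxicity in this test. Nothing given here explains the shift. On these data alone, whether the double bond or the longer link carries the step stays open; a saturated 2-(pyridin-3-yl)ethyl group would separate the two.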